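A few compounds are considered here, and "the series" means these few. Any claim that something is new, unique, unknown or untested is made for them only; others in the source may bear on it.

Of the compounds shown here, two have so far been tested in a functional assay on SK-MEL-5 cells (Homo sapiens) for inhibition, read by sulforhodamine B assay, with a stated time of 48 h; on this read-out higher numbers stand for weaker inhibition of growth and lower numbers for stronger inhibition of growth. Compound 1 `COc1cc(C)cc(-c2nn(CC#N)cc2-c2ccnc(-c3ccc(N(C)C)cc3)c2)c1` gives 672 nM, the lowest of the two numbers. Compound 2 `COc1cc(C)cc(-c2nn(CC#N)cc2-c2ccc(-c3cccc(C(C)=O)c3)nc2)c1` gives 6790 nM in this assay, a weaker result that stands beyond the usual scatter from compound 1; as the two structures differ in several places at once, the gap between them cannot be tied to any single change.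

Compound 3 `Cc1cc(O)cc(-c2nn(CC#N)cc2-c2ccnc(-c3ccc(N(C)C)cc3)c2)c1` has not yet been measured. It differs from compound 1 by hydrogen in place of methyl on an oxygen on an aromatic ring. Among the measured compounds shown here, no measured pair shows this change on its own, so there is no direct precedent. The expected step from compound 1 to compound 3 in this assay is a 1.4-fold higher number from compound 1 to compound 3 (0.15 log units; within the scatter), a small shift toward weaker inhibition of growth that may well lie within the scatter of repeated measurements. Compound 3 is therefore expected to show 950 nM, in the range 300 nM to 3000 nM.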

Compound 3, concentration for total growth inhibition: 5750 nM
Compound 3: the middle estimate sits 6.1-fold (0.78 log units) below what was measured, outside the stated range (above it).
By their numbers in this assay, from the lowest: compound 1; then compounds 3 and 2 (each within the scatter of the next).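

In this assay, among the compounds shown here, the change from methoxy to hydroxy on the 3-methoxy-5-methylphenyl group gives an 8.6-fold higher number from compound 1 to compound 3 (0.93 log units; beyond the scatter) and is the first single change that can be read on its own in this set. The methyl on this oxygen therefore matters here: removing that one carbon while the rest of compound 1 stays the same moves the number beyond the scatter, toward weaker inhibition of growth. The data shown offer nothing that explains this step.

From the compounds shown here alone, it remains open whether an ethoxy group or a longer chain on the same oxygen, or an amine in place of the hydroxy, would keep the number of compound 1 or lose it. Going by these compounds, it also remains open whether the same change would give a step of similar size on compound 2, which differs from compound 1 in several places.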